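A few compounds are considered here, and "the series" means these few. Any claim that something is new, unique, unknown or untested is made for them only; others in the source may bear on it.

Of the compounds shown here, two have so far been measured in a functional assay on cells (Melanoma cell, Homo sapiens) for inhibition; a lower number here means a stronger inhibitor of growth, a higher number a weaker inhibitor of growth. Compound 1, `O=Cc1c(-c2ccc([N+](=O)[O-])cc2)nc2sc(Cc3ccccc3)nn12`, gives 42700 nM in this assay. Compound 2, `O=Cc1c(-c2ccc(F)cc2)nc2sc(CCC3CCCCC3)nn12`, gives 87100 nM in this assay, a weaker result than that of compound 1, so compound 1 stands as the stronger growth inhibitor of the two. These two structures differ in more than one place, so that gap cannot be tied to any single change.

Compound 3, `O=Cc1c(-c2ccc(Br)cc2)nc2sc(Cc3ccccc3)nn12`, has not yet been measured. It differs from compound 1 by bromo in place of nitro on an aromatic carbon, para to a large group. Going by the values given here, no measured pair shows the effect of this particular change, so there is no direct guide to it. The expected step from compound 1 to compound 3 is a 1.2-fold higher number from compound 1 to compound 3 (0.07 log units; within the scatter), which means no shift clearly beyond the usual scatter in either direction. Compound 3 is therefore expected to give about 50000 nM in this assay, within a range from 20000 nM to 120000 nM.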

Compound 3, concentration for total growth inhibition: 19500 nM
Estimate against measurement, compound 3: 2.6-fold (0.41 log units) above, and the stated range ends above it.
By their numbers in this assay, from the lowest: compound 3; then compound 1; then compound 2.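

Going by these compounds alone, the pair measured in this assay is the first here that differs in one place only, and it shows a 2.2-fold lower number from compound 1 to compound 3 (0.34 log units; beyond the scatter) when bromo takes the place of nitro on an aromatic carbon, para to a large group. The step is modest but beyond the scatter, so the number does respond to what sits at this position. The nitro group is also not required for growth inhibition at this level, since the single heavy atom of bromo does at least as well as the 3 heavy atoms of nitro, though no measurement at hand gives a reason for the step.

As far as these compounds go, whether a chloro group, a methoxy group or an amine at this position would lower the number further remains open. So does whether the same swap would give a similar step with a different group elsewhere on the shared core.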